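The source may report more compounds than this note shows. Statements on the series, on what has been measured and on what is new or still open speak of the compounds shown alone.

Notes on a small set of compounds sharing one core, assessed in a functional assay on MDA-MB-231 cells (Homo sapiens) for antiproliferative activity, read by MTT assay, with a stated time of 72 h; a higher number here means a weaker inhibitor, a lower number a stronger inhibitor. Compound 1 `CC(=O)Nc1ccc(S(=O)(=O)Nc2cccc(-c3nc(-c4ccc(NC(=O)c5cccnc5)cc4Cl)no3)c2)cc1C` gives > 10000 nM in this assay, which is a limit of the assay and not a number. Compound 2 `COc1cc(-c2noc(-c3cccc(NS(=O)(=O)c4ccc(NC(C)=O)cc4)c3)n2)ccc1NC(=O)c1cccnc1` likewise returns > 10000 nM in this assay, again only a limit. Compound 3 `O=C(Nc1ccccc1)Nc1cccc(-c2nc(-c3ccc(NC(=O)c4cccnc4)cc3Cl)no2)c1` gives > 10000 nM in this assay, and this too is a limit rather than a measured number. Among the compounds with values here, compound 3 therefore stands exactly where every measured member of the set stands, at the limit of > 10000 nM in this assay, at which 3 of the 3 values shown sit; no step between measured compounds can be drawn, and no difference among compounds 1, 2 and 3 can be read from these values.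

The next compound, compound 4 `CS(=O)(=O)Nc1ccc(NC(=O)Nc2cccc(-c3nc(-c4ccc(NC(=O)c5cccnc5)cc4Cl)no3)c2)cc1Br`, differs from compound 3 in one place: 3-bromo-4-(methanesulfonamido)phenyl in place of phenyl on an amide-type nitrogen. Within the data shown here, with no measured step available, the size of this step in this assay has no precedent within the set; the expectation is of no movement beyond the scatter, or at most a modest gain, since compound 3 sits at the limit of > 10000 nM in this assay, at which 3 of the 3 values shown sit, and its true value beneath that limit is unknown. The estimate for compound 4 in this assay is 8000 nM, expected to lie between 1500 nM and 30000 nM. This corresponds to an expected step of an at least 1.2-fold lower number from compound 3 to compound 4 (0.09 log units; that floor lies within the scatter).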

Compound 4, half-maximal inhibitory concentration: 700 nM
Compound 4: middle estimate off by 11-fold (1.06 log units), on the high side; measured number outside the range, below it.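

The amide-type nitrogen whose other neighbour is the carbonyl carbon proves to be a place where a single change moves the read-out off the limit: in this assay, 3-bromo-4-(methanesulfonamido)phenyl in place of phenyl gives an at least 14-fold lower number from compound 3 to compound 4 (1.15 log units; beyond the scatter). Compound 4 is the only compound shown with a value that is a number rather than a limit, so the group on this nitrogen can carry this core into a measurable range, something compound 1, compound 2 and compound 3 could not show. The printed step is a floor and not a true size, because compound 3 stands at a limit: the limit of > 10000 nM in this assay, at which 3 of the 4 values shown sit.

Going by these compounds, the bromine and the methanesulfonamido group enter together, so the share of each in the step remains open, and a phenyl carrying only one of the two would be needed to separate them. Also open, on these data alone, is how a carboxylic acid or an amine in place of the methanesulfonamido group on that phenyl would read in this assay.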